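The compounds below may be only part of what the source reports. "The series", "measured", "known", "first", "only" and "open" are said of these compounds alone.

Measured so far: compound 1 `COc1cc(N(C)CCCO)ccc1/C=C1\C(=O)N(C2CCCCC2)C(=S)N1C` with 990 nM; compound 2 `COc1cc(N(C)CCCO)ccc1/C=C1\C(=O)N(c2ccccc2)C(=S)N1C` with 2790 nM.

Among the compounds with values here, in an assay on isolated protein for inhibition of NADPH oxidase 2 (Homo sapiens), read by chemiluminescence, in the presence of a further agent that is not named here (on this read-out lower numbers stand for stronger inhibition and higher numbers for weaker inhibition), compound 2 stands highest of the two numbers; the only measured step is a 2.8-fold higher number from compound 1 to compound 2 (0.45 log units; beyond the scatter), a modest change beyond the scatter. Compound 3 `CN1C(=S)N(c2ccccc2)C(=O)/C1=C\c1ccc(N(C)CCCO)cc1O` differs from compound 2 by hydrogen in place of methyl on an oxygen on an aromatic ring. Within the data shown here, no measured step touches this oxygen on the aromatic ring; the step of a 2.8-fold higher number from compound 1 to compound 2 (0.45 log units; beyond the scatter) lies elsewhere in the core and gives no guide. With nothing to go on, a step of a 1.0-fold higher number from compound 2 to compound 3 (0.00 log units; within the scatter) is expected, that is none beyond the scatter. The estimate for compound 3 is 2800 nM, with a range from 1100 nM to 7000 nM.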

Compound 3, half-maximal inhibitory concentration: 6330 nM
Compound 3: the middle estimate sits 2.3-fold (0.35 log units) below what was measured; the range from low to high includes it.
By their numbers in this assay, from the lowest: compound 1; then compound 2; then compound 3.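

In this assay, methoxy to hydroxy on an oxygen on an aromatic ring gives a 2.3-fold higher number from compound 2 to compound 3 (0.36 log units; beyond the scatter), so this position responds to the change, and methoxy gives the stronger inhibition of the two with phenyl held constant. The step is modest and rests on this single pair. No other measurement bears on the origin of this step.

Open, from the compounds shown here alone, is whether ethoxy, a longer chain on this oxygen, or an amine in place of the methoxy would give a lower number than compound 2. Also open, going by these compounds, is whether methoxy to hydroxy gives a step of similar size with the cyclohexyl of compound 1.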